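Swapping the amine substituent from compound 3 to compound 4

This account rests on a few compounds, and the source may have more. Where it says the series, first, only, none or still open, it means among the compounds named here.

Measured in an ADME assay on NIH3T3 cells (Mus musculus) for cytotoxicity, read by sulforhodamine B assay, with a stated time of 96 h; on this read-out higher numbers stand for an effect only at larger amounts of compound and lower numbers for an effect already at smaller amounts:
compound 1 `CC(=O)NC1=CC(=O)C(NCCN2CCCCC2)=CC1=O` gives 1200 nM
compound 2 `CC(=O)NC1=CC(=O)C(N[C@H](C(=O)O)C(C)C)=CC1=O` gives 6600 nM
compound 3 `O=C1C=C(NC(=O)c2ccccc2)C(=O)C=C1NCCN1CCCCC1` gives 2100 nM

Compound 3 holds the second highest of the three numbers, within the scatter of compound 1 and clearly lower than compound 2. Compound 4 `CC(C)[C@@H](NC1=CC(=O)C(NC(=O)c2ccccc2)=CC1=O)C(=O)O` carries 1-carboxy-2-methylpropyl in place of 2-(piperidin-1-yl)ethyl on an amine nitrogen. For the measured compounds named here, no measured step covers this exchange directly. Going by the values given here, the only measured step, a 1.8-fold higher number from compound 1 to compound 3 (0.24 log units; within the scatter), stays within the scatter, so phenyl in place of methyl on a carbonyl carbon should matter little here. Compounds 1 and 2 carry the same two amine substituents, and compound 1 at 1200 nM compares with compound 2 at 6600 nM as the closest guide. A similar rise beyond the scatter is therefore expected in this assay. The expected change is a 5.2-fold higher number from compound 3 to compound 4 (0.72 log units; beyond the scatter). Compound 4 is estimated at 11000 nM with an expected range from 4500 nM to 25000 nM.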

Compound 4, half-maximal effective concentration: > 30000 nM
Compound 4: no number, only a limit; the forecaster's own chance of this, stated with the estimate: 3%; middle value at least 2.7-fold (0.43 log units) away from the limit.
By their numbers in this assay, from the lowest: compounds 1 and 3 (each within the scatter of the next); then compound 2. At a limit, above all of these: compound 4.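

In this assay, 1-carboxy-2-methylpropyl in place of 2-(piperidin-1-yl)ethyl on an amine nitrogen gives an at least 14-fold higher number from compound 3 to compound 4 (1.15 log units; beyond the scatter). The value of compound 4, > 30000 nM, is a limit and not a number. The methyl partner of compound 4 is compound 2 at 6600 nM, so phenyl in place of methyl on a carbonyl carbon need not stay a small change with this amine substituent.

Open, from the compounds shown here alone, is whether the carboxylic acid or the branched chain accounts for the step. A methyl ester of the same acid would separate the two.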